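Swapping the aryl group on the sulfonyl in a quinoline series

The source may report more compounds than this note shows. Statements on the series, on what has been measured and on what is new or still open speak of the compounds shown alone.

Of the compounds shown here, three have been measured in an assay on isolated protein for displacement of a labelled ligand from metabotropic glutamate receptor 5 (Homo sapiens), with a stated time of 60 min, tested at 1 uM; a lower number here means less inhibition, a higher number more inhibition at the concentration tested (going by the name of the read-out). Compound 1 `COc1ccc(S(=O)(=O)c2cnc3ccc(C)cc3c2N2CCC(C)CC2)cc1Cl` gives 93%, compound 2 `CC1CCN(c2c(S(=O)(=O)c3cccc(Cl)c3)cnc3ccc(Cl)cc23)CC1` gives 92%, and compound 3 `CC1CCN(c2c(S(=O)(=O)c3ccc(F)cc3)cnc3ccc(Cl)cc23)CC1` gives 89%. Compound 3 thus holds the lowest of the three numbers, though its gaps to the others lie within the scatter, so the three cannot be told apart. The one single-point step shown, a number 3 percentage points lower from compound 2 to compound 3 (within the scatter), is also within the scatter. Compound 4 `COc1ccc(S(=O)(=O)c2cnc3ccc(Cl)cc3c2N2CCC(C)CC2)cc1Cl` carries 3-chloro-4-methoxyphenyl in place of 4-fluorophenyl on a sulfonyl sulfur. The step from compound 2 to compound 3 suggests the aryl group on the sulfonyl sulfur changes little, and compound 1 carries the same incoming group. Compound 4 is expected to give 92%, between 85% and 98%, because compound 1 gives 93%. The expected step of a number 3 percentage points higher from compound 3 to compound 4 (within the scatter) stays within the scatter.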

Compound 4, a percentage reported as inhibition, at one concentration (the size of the read-out at that concentration, not a potency): 46%
The estimate for compound 4 lay 46 percentage points above the measured number; measured number outside the range, below it.
By their numbers in this assay, from the lowest: compound 4; then compounds 3, 2 and 1 (each within the scatter of the next).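

In this assay, the aryl group on the sulfonyl sulfur proves not to be freely exchangeable: 3-chloro-4-methoxyphenyl in place of 4-fluorophenyl gives a number 43 percentage points lower from compound 3 to compound 4 (beyond the scatter). Methoxy in place of hydrogen on an aromatic carbon gives a number 46 percentage points lower from compound 2 to compound 4 (beyond the scatter). Compound 1 carries the same aryl group, yet chloro in place of methyl on an aromatic carbon gives a number 47 percentage points lower from compound 1 to compound 4 (beyond the scatter), so the effect of this aryl group depends on what else sits on the shared core.

No available data explain these drops. From the compounds shown here alone, whether ethoxy or an amine in place of the methoxy of compound 4 would change its number remains open.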